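A few compounds are considered here, and "the series" means these few. Any claim that something is new, unique, unknown or untested is made for them only; others in the source may bear on it.

Compound 1 `C=CC(=O)Nc1cccc(Oc2nc(Nc3cccc(OC)c3)nc3ccsc23)c1` is an acrylamide; in a functional assay on A-431 cells (Homo sapiens) for inhibition, read by MTT assay, with a stated time of 72 h (on this read-out lower numbers stand for stronger inhibition and higher numbers for weaker inhibition), compound 1 gives 4790 nM. Compound 2 `C/C=C/C(=O)Nc1cccc(Oc2nc(Nc3cccc(OC)c3)nc3ccsc23)c1` carries prop-1-en-1-yl in place of vinyl on the carbonyl carbon, and in this assay compound 2 gives 13100 nM. Among the two measured numbers, compound 2 stands highest; the only step recorded so far, a 2.7-fold higher number from compound 1 to compound 2 (0.44 log units; beyond the scatter), shows the weaker inhibition that came with the extra carbon on the double bond.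

Compound 3 `COc1cccc(Nc2nc(Oc3cccc(NC(=O)C=C(C)C)c3)c3sccc3n2)c1` is not yet measured. Relative to compound 2 the change is 2-methylprop-1-en-1-yl in place of prop-1-en-1-yl on a carbonyl carbon, which puts a second methyl on the same double bond. Among the compounds with values here, only the step of a 2.7-fold higher number from compound 1 to compound 2 (0.44 log units; beyond the scatter) bears on this, and it is of modest size. Repeating the same direction of change suggests that this assay would again report a higher number, though whether the second methyl costs as much as the first cannot be read from two points. Compound 3 is therefore expected to show a further weakening, a 1.9-fold higher number from compound 2 to compound 3 (0.28 log units; within the scatter), and its estimated value in this assay is 25000 nM, in the range 9000 nM to 70000 nM.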

Compound 3, half-maximal inhibitory concentration: 25800 nM
For compound 3 the middle estimate is 1.0-fold (0.01 log units) below the measured one; measured number inside the range.
By their numbers in this assay, from the lowest: compound 1; then compounds 2 and 3 (each within the scatter of the next).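

Placing a second methyl on the double bond, a 2.0-fold higher number from compound 2 to compound 3 (0.29 log units; within the scatter), leaves compound 2 and compound 3 indistinguishable in this assay, so the step beyond the scatter seen with the first methyl does not clearly repeat at this position. The wider comparison is more informative: a 5.4-fold higher number from compound 1 to compound 3 (0.73 log units; beyond the scatter) lies beyond the scatter, so among these three compounds, the vinyl of compound 1 gives a lower number than both the prop-1-en-1-yl of compound 2 and the 2-methylprop-1-en-1-yl of compound 3. No measurement shown here explains this trend on the carbonyl carbon, and its cause remains unestablished.

All three compounds keep a double bond in this group, so the shown data cannot say how a saturated ethyl group on the carbonyl carbon, or a dimethylamino group carried at the end of the prop-1-en-1-yl chain, would compare. Every number also comes from this assay, leaving open whether the same ranking would hold on another cell line or in a test on an isolated enzyme.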